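Cyanoaziridine ureas: amine replacement on the urea nitrogen

The compounds below may be only part of what the source reports. "The series", "measured", "known", "first", "only" and "open" are said of these compounds alone.

Measured so far in a functional assay on WiDr cells (Homo sapiens) for inhibition; a lower number here means a stronger inhibitor, a higher number a weaker inhibitor:
compound 1, `N#CC1CN1C(=O)Nc1ccc(F)cc1`: 9000 nM
compound 2, `CC(C)(C)NC(=O)N1CC1C#N`: > 300000 nM
compound 3, `N#CC1CN1C(=O)Nc1cccnc1`: 18000 nM

Compound 1 and compound 3 carry an aryl group on the urea nitrogen and give numbers. Compound 2 carries tert-butyl there, and its value is a limit of this assay, (the limit of > 300000 nM in this assay, at which 1 of the 3 values shown sits), not a number. Compound 4, `CNC(=O)N1CC1C#N`, keeps the core of compound 2 and differs only by methyl in place of tert-butyl on an amide-type nitrogen. Among the measured compounds shown here, no measured pair isolates this change. Compound 4 is expected to stay near the limit, with no step beyond the scatter from compound 2, and an estimate of 300000 nM (range 100000 nM to 1000000 nM), which means a number no higher from compound 2 to compound 4 (the limit leaves the size open).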

Compound 4, half-maximal inhibitory concentration: 23000 nM
Compound 4: middle estimate off by 13-fold (1.12 log units), on the high side; measured number outside the range, below it.
By their numbers in this assay, from the lowest: compounds 1, 3 and 4 (each within the scatter of the next, the first and the last beyond it). At a limit, above all of these: compound 2.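

In this assay, the alkyl group on the amide-type nitrogen matters: methyl in place of tert-butyl gives an at least 13-fold lower number from compound 2 to compound 4 (1.11 log units; beyond the scatter). The value of compound 2 is a limit, not a number: the limit of > 300000 nM in this assay, at which 1 of the 4 values shown sits. Compound 4 gives a number with no aryl group on that nitrogen, so an aryl group is not required for a measurable value.

As far as these compounds go, whether ethyl or isopropyl on the same nitrogen gives a number remains open, as does the point along that alkyl series where the limit is reached. Also open, from the compounds shown here alone, is how a benzyl group or a hydroxyethyl chain would read there.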